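A few compounds are considered here, and "the series" means these few. Any claim that something is new, unique, unknown or untested is made for them only; others in the source may bear on it.

Three compounds that share the core of compound 1 `OCC(O)Cn1nc2c(Br)c(Br)c(Br)c(Br)c2n1` have been tested in a functional assay on MCF7 cells (Homo sapiens) for antiproliferative activity, read by MTT assay, with a stated time of 48 h, tested at 100 uM; on this read-out higher numbers stand for a weaker effect at the one concentration tested and lower numbers for a stronger effect. Compound 1 gives 8%, a number that sits within the scatter of compound 3 `OC(CCn1nc2c(Br)c(Br)c(Br)c(Br)c2n1)c1cccc(Cl)c1` at 0.5% and of compound 2 `OC(CCn1nc2c(Br)c(Br)c(Br)c(Br)c2n1)c1ccc(Br)cc1` at 0%. Going by the values given here, the only measured step among them, a number 0.5 percentage points higher from compound 2 to compound 3 (within the scatter), exchanges one aryl group for another on a saturated chain carbon bound to an oxygen and leaves the chain attached to the core untouched. Compound 4 `CC(O)CCn1nc2c(Br)c(Br)c(Br)c(Br)c2n1` is the next case: 2-hydroxypropyl in place of 1,2-dihydroxyethyl on a saturated chain carbon bound to an aromatic nitrogen. Among the compounds with values here, no measured step bears on this change, so no step beyond the scatter is expected in this assay. Compound 4 is therefore estimated to give 6%, between 0% and 18%, an expected step of a number 2 percentage points lower from compound 1 to compound 4 (within the scatter).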

Compound 4, a percentage reported as activity, at one concentration (the size of the read-out at that concentration, not a potency): 0%
Compound 4: the middle estimate sits 6 percentage points above what was measured; the range from low to high includes it.
By their numbers in this assay, from the lowest: compounds 2, 4, 3 and 1 (each within the scatter of the next).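

The change of 2-hydroxypropyl in place of 1,2-dihydroxyethyl on a saturated chain carbon bound to an aromatic nitrogen gives a number 8 percentage points lower from compound 1 to compound 4 (within the scatter), so this place now has a reading of its own. Methyl in place of 3-chlorophenyl gives a number 0.5 percentage points lower from compound 3 to compound 4 (within the scatter), and methyl in place of 4-bromophenyl gives no change at the digits printed from compound 2 to compound 4 (within the scatter), so the read-out does not separate methyl from either aryl group. No measurement offered here explains these results. From the compounds shown here alone, whether an amine, a carboxylic acid or a longer chain at this place would give a step beyond the scatter remains open.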